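Working notes: carbonyl substituent exchange and maximal response

The compounds below may be only part of what the source reports. "The series", "measured", "known", "first", "only" and "open" are said of these compounds alone.

Measured compounds:
compound 1, `Cc1ccc(C)c(C(=O)NC(CCN(C)C)c2ccc(Cl)cc2)c1`, 164%
compound 2, `Cc1cc(C)c(C(=O)NC(CCN(C)C)c2ccc(Cl)cc2)cc1C`, 159%
compound 3, `CN(C)CCC(OC(=O)Nc1ccc2ccccc2c1)c1ccc(Cl)cc1`, 89%

In an assay on NIH3T3 cells with Urotensin-2 receptor (Homo sapiens) as the target (a lower number here means a smaller maximal response, a higher number a larger maximal response), compound 1 gives 164%, the highest of the three numbers. Compound 2 sits nearest, with the step of a number 5 percentage points lower from compound 1 to compound 2 (within the scatter), which is methyl in place of hydrogen on an aromatic carbon and lies within the scatter. Among the compounds with values here, compound 3 gives 89% in this assay; it differs from compound 1 in more than one place, so no single step is defined for that pair, and its value stands a long way below the other two.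

Compound 4, `CN(C)CCC(NC(=O)NCc1ccccc1)c1ccc(Cl)cc1`, differs from compound 1 by benzylamino in place of 2,5-dimethylphenyl on a carbonyl carbon. Within the data shown here, no measured step touches the group on the carbonyl carbon; the only step on hand, from compound 1 to compound 2, changes a distant ring methyl and is within the scatter. The two measured values of the shared core, compound 1 and compound 2, are both high, whereas compound 3 shows that larger rearrangements of the carbonyl part can bring the maximal response far down.

The step from compound 1 to compound 4 is therefore expected to be a number 49 percentage points lower from compound 1 to compound 4 (beyond the scatter), downward, with wide uncertainty. For compound 4 the expected value in this assay is 115%, between 70% and 160%.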

Compound 4, largest response reached (reported as efficacy), in percent of the reference or control that the assay uses: 179%
Compound 4: middle estimate off by 64 percentage points, on the low side; measured number outside the range, above it.
By their numbers in this assay, from the lowest: compound 3; then compounds 2 and 1 (each within the scatter of the next); then compound 4.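

Within the data shown here, this is the first step read at the group on the carbonyl carbon itself: in this assay benzylamino in place of 2,5-dimethylphenyl gives a number 15 percentage points higher from compound 1 to compound 4 (beyond the scatter), modest in size but beyond the scatter. The position therefore accepts a urea-type link, with an amide-type nitrogen on each side of the carbonyl carbon, and the maximal response of compound 4 stays at 179%; the earlier step, a ring methyl on the 2,5-dimethylphenyl group, did not reach this position. With the heavy-atom total and the aromatic ring count the same in both groups, the exchange brings in one nitrogen and one hydrogen-bond donor, but nothing on hand says what lies behind the step.

The compounds shown leave open whether the response depends on the chain linking the nitrogen to the ring, as a phenylamino or a 2-phenylethylamino group on the carbonyl carbon would test. They also leave open whether an aromatic ring is needed there at all, which a cyclohexylamino group would address, and how a chlorine or methoxy substituent on the benzylamino ring would change the response.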